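The source may report more compounds than this note shows. Statements on the series, on what has been measured and on what is new or still open speak of the compounds shown alone.

Working notes on the series. Compound 2 (`CCOC(=O)CCCCCOc1cccc(CN(C(=O)c2ccc(-c3ccc(Cl)c(Cl)c3)cc2)C(C)C)c1`) stands in an ADME assay on HepG2 cells (Homo sapiens) for cytotoxicity, read by CellTiter-Glo and resazurin assay, with a stated time of 72 h (on this read-out lower numbers stand for an effect already at smaller amounts and higher numbers for an effect only at larger amounts of compound), only at a limit of the assay: compound 2 gives > 26000 nM. Compound 1 (`CCOC(=O)CCCCCOc1cccc(CN(C(=O)c2ccc(-c3cc(OC)cc(OC)c3)cc2)C(C)C)c1`) likewise gives a limit: in this assay compound 1 gives > 26000 nM. Within the data shown here, the one measured step, a step that the two limits leave unreadable from compound 1 to compound 2, is therefore not readable in size, and all that can be said rests on (the limit of > 26000 nM in this assay, at which 2 of the 2 values shown sit).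

Compound 3 (`CCOC(=O)CCCCCOc1cccc(CN(C(=O)c2ccc(-c3cccc(Cl)c3)cc2)C(C)C)c1`) differs from compound 2 by hydrogen in place of chloro on an aromatic carbon. Among the measured compounds shown here, no measured step bears on a change of this kind; the only step on record, from a 3,5-dimethoxyphenyl to a 3,4-dichlorophenyl group, is unreadable. With two limits and no readable step, the expectation for compound 3 is that it, too, stays at the limit in this assay, and the step that the limit leaves unreadable from compound 2 to compound 3 is estimated as none beyond the scatter. Compound 3 is thus expected at 40000 nM, within 20000 nM to 100000 nM.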

Compound 3, half-maximal effective concentration: > 18400 nM
Compound 3: a limit, no number (the forecaster's own chance of this, stated with the estimate: 85%); the middle value does not contradict the limit.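

In this assay, among these compounds, compound 1, compound 2 and compound 3 all give only limits of the assay, and no step among them can be read in size. Left open is the concentration at which any of the three reaches a half-maximal effect, and whether the changes between them shift it at all.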